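The source may hold more compounds than are shown below. What is called first, only, known or untested is meant among the compounds shown, and "the series" means these compounds.

Of the compounds shown here, two have so far been measured in a functional assay on PC-3 cells (Homo sapiens) for inhibition, read by MTT assay, with a stated time of 48 h; a lower number here means a stronger inhibitor, a higher number a weaker inhibitor. Compound 1, `COc1ccc(-n2c(SCC(=O)C3CC3)nnc2-c2cc(OC)c(OC)c(OC)c2)cc1`, carries a short chain on its sulfur, and in this assay compound 1 gives 37200 nM. Compound 2, `COc1cc(-c2nnc(S)n2-c2ccc(N(C)C)cc2)cc(OC)c1OC`, has a bare sulfanyl group at that position instead. For compound 2 this assay reports only the limit > 60000 nM, so no number is known for it. The line the limit of > 60000 nM in this assay, at which 1 of the 2 values shown sits, marks where that limit sits. For the measured compounds named here, compound 2 thus stands at the weak end of the two values shown, the only number belonging to compound 1.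

Compound 3, `COc1cc(-c2nnc(SCC(=O)Nc3ccc(Cl)cc3)n2-c2ccc(N(C)C)cc2)cc(OC)c1OC`, differs from compound 2 in one place: ((4-chlorophenyl)carbamoyl)methyl in place of hydrogen on a sulfur. No step between two measured compounds is available, so the size of this move must be guessed from what is shown. Compound 1 reaches 37200 nM with a chain on its sulfur, while compound 2 gives no number, so adding a chain is expected to improve the result. The step from compound 2 to compound 3 is expected to be a gain of about an at least 2.0-fold lower number from compound 2 to compound 3 (0.30 log units; that floor lies within the scatter), beyond the scatter. Compound 3 is therefore expected to give roughly 30000 nM, with a likely range from 8000 nM to 70000 nM.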

Compound 3, half-maximal inhibitory concentration: > 60000 nM
Compound 3 gave a limit, no number; the forecaster's own chance of this, stated with the estimate: 25%; middle value at least 2.0-fold (0.30 log units) from the limit.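

In this assay compound 3 gives only a limit, > 60000 nM, not a number. Compound 2 also has only a limit, so no step from compound 2 to compound 3 can be read: the limit of > 60000 nM in this assay, at which 2 of the 3 values shown sit.

From the compounds shown here alone, whether ((4-chlorophenyl)carbamoyl)methyl in place of hydrogen on a sulfur changes the result at all remains open.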